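A few compounds are considered here, and "the series" means these few. Any claim that something is new, unique, unknown or untested is made for them only; others in the source may bear on it.

Measured so far:
compound 1 `COc1cc(OC)c(-c2coc3cc(OCC=C(C)C)ccc3c2=O)cc1OC` — 280 nM
compound 2 `COc1cc(OC)c(-c2coc3cc(OCc4ccccc4F)ccc3c2=O)cc1OC` — 1280 nM

In a functional assay on HepG2 cells (Homo sapiens) for antiproliferative activity, read by MTT assay, with a stated time of 24 h (on this read-out lower numbers stand for stronger inhibition and higher numbers for weaker inhibition), compound 2 gives 1280 nM, the highest of the two numbers seen. The nearest is compound 1, which gives 280 nM. Within the data shown here, the one step available is a 4.6-fold higher number from compound 1 to compound 2 (0.66 log units; beyond the scatter), a 2-fluorophenyl in place of 2-methylprop-1-en-1-yl on a saturated chain carbon bound to an oxygen on an aromatic ring.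

Compound 3 `COc1cc(OC)c(-c2coc3cc(OCc4cccc(Br)c4)ccc3c2=O)cc1OC` differs from compound 2 in 3-bromophenyl in place of 2-fluorophenyl on a saturated chain carbon bound to an oxygen on an aromatic ring. The measured step bears on it only loosely: it shows that the group on the saturated chain carbon bound to an oxygen on an aromatic ring moves the read-out, but it exchanged an open chain for a ring, whereas here one six-membered aromatic ring of carbon only is exchanged for another of the same size, with the halogen changed and placed differently. Among the measured compounds shown here, no pair of measured compounds compares two such rings, so the direction cannot be read from the data. The expected step, a 1.1-fold lower number from compound 2 to compound 3 (0.03 log units; within the scatter), is therefore small and within the scatter. Compound 3 is estimated at 1200 nM, with a range of 450 nM to 3200 nM.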

Compound 3, half-maximal inhibitory concentration: 870 nM
Beside the measured number, compound 3's estimate is 1.4-fold (0.14 log units) above it; low and high end bracket the measured number.
By their numbers in this assay, from the lowest: compound 1; then compounds 3 and 2 (each within the scatter of the next).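

In this assay the ring exchange on the saturated chain carbon bound to an oxygen on an aromatic ring gives a 1.5-fold lower number from compound 2 to compound 3 (0.17 log units; within the scatter) and so does not separate 2-fluorophenyl from 3-bromophenyl, even though the halogen and its place on the ring both differ. The open chain now stands against two rings, with a 3.1-fold higher number from compound 1 to compound 3 (0.49 log units; beyond the scatter) as a second step beyond the scatter in the same direction as the first, so among these three compounds the 2-methylprop-1-en-1-yl of compound 1 gives the lowest number and neither halogenated ring matches it. No independent measurement is available to explain either the gap between chain and rings or the closeness of the two rings.

With both the halogen and its place changed in one step, their separate contributions remain unresolved, and a plain phenyl or a 3-fluorophenyl would be needed to pull them apart. Going by these compounds, it also remains open how a longer alkyl chain, or a chain ending in an amine, would compare with 2-methylprop-1-en-1-yl at this position.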